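The source may hold more compounds than are shown below. What is called first, only, known or untested is meant among the compounds shown, and "the series" means these compounds.

Compound 1 `O=c1nc(-c2ccccc2Cl)ss1` is tested in an ADME assay on L02 cells (Homo sapiens) for inhibition, read by MTT assay, with a stated time of 48 h, tested at 100 uM (a higher number here means more inhibition at the concentration tested (going by the name of the read-out), a lower number less inhibition), where compound 1 gives 40.1%. Compound 2 `O=c1nc(-c2ccccc2[N+](=O)[O-])ss1` carries one change against compound 1, (nitro in place of chloro on an aromatic carbon), and in this assay compound 2 gives 33%; the step of a number 7.1 percentage points lower from compound 1 to compound 2 (within the scatter) is small. Compound 3 `O=c1oc(-c2ccccc2Cl)ns1` rests on a different core, and the difference between the two cores is not broken down here. In this assay compound 3 gives 20.6%, the lowest of the three numbers. Compound 4 `O=c1oc(-c2ccccc2[N+](=O)[O-])ns1` is compound 3 with the same change, (nitro in place of chloro on an aromatic carbon), not yet measured in this assay. Given that compound 1 moved only by a number 7.1 percentage points lower from compound 1 to compound 2 (within the scatter), the step from compound 3 to compound 4 is expected to be about a number 5.6 percentage points lower from compound 3 to compound 4 (within the scatter). Compound 4 is therefore estimated at 15%, between 5% and 28%.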

Compound 4, a percentage reported as inhibition, at one concentration (the size of the read-out at that concentration, not a potency): 32.4%
For compound 4 the middle estimate is 17.4 percentage points below the measured one; measured number outside the range, above it.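

On the core of compound 3, nitro in place of chloro gives a number 11.8 percentage points higher from compound 3 to compound 4 (beyond the scatter) in this assay. The change therefore does not carry over as a fixed step between these two cores: the same change on two cores in this assay, a number 7.1 percentage points lower (within the scatter) from compound 1 to compound 2 and a number 11.8 percentage points higher (beyond the scatter) from compound 3 to compound 4, 18.9 percentage points apart, beyond the scatter of two such steps This rests on a single pair on each core and shows only that the size and direction of the step differ between these two cores; it does not show why they differ or what the change would do on any other core.

The compounds shown carry only chloro or nitro on the six-membered aromatic ring of carbon only. As far as these compounds go, whether an amine or a carboxylic acid at that place would also behave differently on the two cores stays open.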